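A few compounds are considered here, and "the series" means these few. Any claim that something is new, unique, unknown or untested is made for them only; others in the source may bear on it.

Measured so far in a functional assay on HCT-116 cells (Homo sapiens) for cytotoxicity, read by sulforhodamine B assay, with a stated time of 48 h; a lower number here means a stronger inhibitor, a higher number a weaker inhibitor:
compound 1 `CO[C@@H]1CC=C2N(c3ccc(C)cc3)C(=O)C[C@]2(c2ccccc2)O1`, giving 4300 nM
compound 2 `CO[C@@H]1CC=C2N(c3ccc4[nH]ccc4c3)C(=O)C[C@]2(c2ccccc2)O1`, giving 5300 nM

Compound 2 and compound 1 lie close together: the step of a 1.2-fold higher number from compound 1 to compound 2 (0.09 log units; within the scatter) is within the scatter, so the two numbers cannot be told apart on this evidence. Compound 3 `CO[C@@H]1CC=C2N(c3cc(Cl)cc(Cl)c3)C(=O)C[C@]2(c2ccccc2)O1` has not yet been measured in this assay. It differs from compound 2 in one place: 3,5-dichlorophenyl in place of 1H-indol-5-yl on an amide-type nitrogen in a ring. Within the data shown here, the only measured step that bears on this change is the one at the same amide-type nitrogen, a 1.2-fold higher number from compound 1 to compound 2 (0.09 log units; within the scatter), in which exchanging one aryl group for another left the number within the scatter. On that basis no step beyond the scatter is expected here either, though a single example is thin support. For compound 3 the expected value in this assay is 4500 nM, within a range from 1500 nM to 14000 nM. The step of a 1.2-fold lower number from compound 2 to compound 3 (0.07 log units; within the scatter) is estimated to stay inside the scatter.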

Compound 3, half-maximal inhibitory concentration: 11200 nM
For compound 3 the middle estimate is 2.5-fold (0.40 log units) below the measured one; low and high end bracket the measured number.
By their numbers in this assay, from the lowest: compounds 1 and 2 (each within the scatter of the next); then compound 3.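

In this assay the steps of a 2.1-fold higher number from compound 2 to compound 3 (0.32 log units; beyond the scatter) and a 2.6-fold higher number from compound 1 to compound 3 (0.42 log units; beyond the scatter) show that the aryl group on the amide-type nitrogen can change the number beyond the scatter, though only modestly. Until now, 4-methylphenyl and 1H-indol-5-yl could not be told apart at this position, whereas 3,5-dichlorophenyl gives a weaker inhibitor than either. No measurement shown here accounts for this shift.

It remains open whether the chlorine atoms or their placement on the ring matter, since a phenyl ring with a single chlorine or with two methyl groups in the same places is not among the compounds shown. On these data alone, how an aryl group carrying an amine or a carboxylic acid, or a plain alkyl chain on this nitrogen, would behave also stays unknown.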